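A heteroaryl exchange in a series sitting at the limit

The source may hold more compounds than are shown below. What is called first, only, known or untested is meant among the compounds shown, and "the series" means these compounds.

In an ADME assay on NIH3T3 cells (Mus musculus) for cytotoxicity (a lower number here means that less compound is needed, a higher number that more compound is needed for the effect), compound 1 `Cc1cc([N+](=O)[O-])ccc1Nc1cccc(Cn2ccnc2)c1` gives > 100000 nM as a limit of the assay and not a number. Compound 2 `Cc1cc(Oc2cccc(Cn3cccn3)c2)cc(C)c1Cl` gives > 100000 nM as a limit as well and not a number. For the measured compounds named here, the series so far stands at the limit of > 100000 nM in this assay, at which 2 of the 2 values shown sit, and compound 2 therefore has no exact number to serve as a starting point. Going by the values given here, no step between measured compounds that differ in one place is available yet in this assay for comparison.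

Compound 3 `Cc1nnc(Cc2cccc(Oc3cc(C)c(Cl)c(C)c3)c2)s1` carries 5-methyl-1,3,4-thiadiazol-2-yl in place of 1H-pyrazol-1-yl on a saturated chain carbon bound to an aromatic carbon and is otherwise the same as compound 2. The expected change is an at least 1.1-fold lower number from compound 2 to compound 3 (0.04 log units; that floor lies within the scatter) and no size beyond the usual scatter is foreseen in either direction. A reading that again returns only the limit is the likeliest outcome for compound 3. For compound 3 an estimated 90000 nM is expected with 35000 nM to 150000 nM as the expected range.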

Compound 3, half-maximal effective concentration: 3800 nM
Compound 3: middle estimate off by 24-fold (1.37 log units), on the high side; the whole stated range lies above it.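

In this assay, the exchange of 1H-pyrazol-1-yl for 5-methyl-1,3,4-thiadiazol-2-yl on a saturated chain carbon bound to an aromatic carbon, with the rest of the structure unchanged, gives an at least 26-fold lower number from compound 2 to compound 3 (1.42 log units; beyond the scatter). This place on the shared core is therefore not silent, and a single heteroaryl exchange there is enough to move the read-out off the limit. For the compounds shown here, compound 3 stands at 3800 nM, the only exact number among the values shown. The step gives only a floor for the size of the change, because its starting point has no exact value: the limit of > 100000 nM in this assay, at which 2 of the 3 values shown sit.

The exchange changes the ring and adds the methyl group in one step, and the compounds shown do not separate the contribution of the 1,3,4-thiadiazole ring from that of its methyl group, which an unsubstituted 1,3,4-thiadiazol-2-yl would address. From the compounds shown here alone, it also remains open how other groups at this place would read in this assay, such as a primary amine or a carboxylic acid, and whether the same exchange would have a similar effect on the core of compound 1.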